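The source may hold more compounds than are shown below. What is called first, only, known or untested is meant among the compounds shown, and "the series" means these compounds.

Measured so far:
compound 1 `COc1cc2c(Oc3ccc(NC(=O)N/N=C/c4ccc(F)cc4Cl)cc3F)ccnc2cc1OCCCN1CCCCC1` — 130 nM
compound 2 `COc1cc2c(Oc3ccc(NC(=O)N/N=C/c4ccc(Cl)cc4Cl)cc3F)ccnc2cc1OCCCN1CCCCC1` — "not determined" (no result reported)

In a functional assay on A549 cells (Homo sapiens) for cytotoxicity, read by MTT assay, with a stated time of 72 h (on this read-out higher numbers stand for weaker inhibition and lower numbers for stronger inhibition), compound 1 gives 130 nM. Compound 2 has no result in this assay; its entry reads "not determined" (no result reported), so no single number places it in the series. Compound 3 `COc1cc2c(Oc3ccc(NC(=O)N/N=C/c4ccc(OC(F)(F)F)cc4)cc3F)ccnc2cc1OCCCN1CCCCC1` differs from compound 2 by 4-(trifluoromethoxy)phenyl in place of 2,4-dichlorophenyl on a carbon with a double bond to nitrogen. For the measured compounds named here, no measured step covers this pair, so in this assay no shift beyond the usual scatter is expected in either direction; the only anchor is compound 1 at 130 nM. Compound 3 is expected near 200 nM, within 50 nM to 800 nM.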

Compound 3, half-maximal inhibitory concentration: 590 nM
Compound 3: middle estimate off by 3.0-fold (0.47 log units), on the low side, and the stated range covers the measured number.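

In this assay, the aryl group on the carbon with a double bond to nitrogen is not neutral: 4-(trifluoromethoxy)phenyl in place of 2-chloro-4-fluorophenyl gives a 4.5-fold higher number from compound 1 to compound 3 (0.66 log units; beyond the scatter) and the number moves beyond the scatter. The step between compound 2 and compound 3 cannot be read, as compound 2 has no value. Nothing on hand accounts for the shift. Still open, on these data alone, is whether the higher number in compound 3 follows from losing the chlorine or from gaining trifluoromethoxy. As far as these compounds go, how an unsubstituted phenyl or a 4-aminophenyl group would read here also remains unknown.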